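A few compounds are considered here, and "the series" means these few. Any claim that something is new, unique, unknown or untested is made for them only; others in the source may bear on it.

Measured so far:
- compound 1 `N[C@H]1C[C@@H](N2Cc3cn(S(=O)(=O)C4CCCC4)nc3C2)CO[C@@H]1c1cc(F)ccc1F`: 41 mL/min/kg
- compound 2 `CCC(=O)Nc1n[nH]c2c1CN([C@H]1CO[C@H](c3cc(F)ccc3F)[C@@H](N)C1)C2`: 60 mL/min/kg

In an ADME assay on the whole organism (plasma) for pharmacokinetics, with Rattus norvegicus as the target (a higher number here means faster removal of the compound, a lower number slower removal), compound 2 gives 60 mL/min/kg. This lies within the scatter of compound 1 at 41 mL/min/kg, so the two numbers cannot be ranked.

The next compound is compound 3 `CS(=O)(=O)Nc1n[nH]c2c1CN([C@H]1CO[C@H](c3cc(F)ccc3F)[C@@H](N)C1)C2`, which differs from compound 2 by methylsulfonyl in place of propanoyl on a nitrogen on an aromatic ring. For the measured compounds named here, no measured pair shows this change or any other single-place change, so the data give no direct guide to its size or direction. The two measured compounds sit close together, and the expectation stays near them. The expected change is a 1.3-fold lower number from compound 2 to compound 3 (0.10 log units; within the scatter), which would not go beyond the scatter. For compound 3 the estimated value in this assay is 48 mL/min/kg, with an expected range of 22 mL/min/kg to 85 mL/min/kg.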

Compound 3, clearance: 16 mL/min/kg
The estimate for compound 3 lay 3.0-fold (0.48 log units) above the measured number; the whole stated range lies above it.
By their numbers in this assay, from the lowest: compound 3; then compounds 1 and 2 (each within the scatter of the next).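

Methylsulfonyl in place of propanoyl on a nitrogen on an aromatic ring gives a 3.8-fold lower number from compound 2 to compound 3 (0.57 log units; beyond the scatter) in this assay. For the compounds shown here, this is the first single-place step, and it shows that the group at this position can move the number beyond the scatter. Both groups hold the same number of heavy atoms, so the step comes with a change in the atoms themselves and not in that count, and no measurement at hand accounts for it.

As far as these compounds go, this reading rests on one pair, so it remains open whether the lower number holds for other sulfonyl groups, such as ethylsulfonyl with its longer chain. From the compounds shown here alone, it is also open where a urea or a free amine at the same nitrogen would fall.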